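From furan-2-yl to 3-methyl-1,2,4-oxadiazol-5-yl on the chain

The source may hold more compounds than are shown below. What is called first, only, known or untested is meant among the compounds shown, and "the series" means these compounds.

Values so far in a functional assay on SNB-19 cells (Homo sapiens) for inhibition, read by MTT assay, with a stated time of 7 days (a lower number here means a stronger inhibitor of growth, a higher number a weaker inhibitor of growth), each one a limit:
Compound 1 (`COc1ccc(Cn2nnc3c(C(N)=O)ncn3c2=O)cc1`) gives > 50000 nM as a limit
Compound 2 (`COc1ccc(Cn2nnc3c(C(N)=O)ncn3c2=O)cc1OC`) gives > 50000 nM as a limit
Compound 3 (`NC(=O)c1ncn2c(=O)n(Cc3ccco3)nnc12`) gives > 50000 nM as a limit

Compound 3 stands at > 50000 nM as a limit and not as a number. The whole series rests there (the limit of > 50000 nM in this assay, at which 3 of the 3 values shown sit). Compound 4 (`Cc1noc(Cn2nnc3c(C(N)=O)ncn3c2=O)n1`) carries 3-methyl-1,2,4-oxadiazol-5-yl in place of furan-2-yl on a saturated chain carbon bound to an aromatic nitrogen. Going by the values given here, the only measured step (a step that the two limits leave unreadable from compound 1 to compound 2) has no readable size, so no step beyond the scatter is expected in this assay and a further limit is the likely report. The expected change is a number no higher from compound 3 to compound 4 (the limit leaves the size open) and no more. For compound 4 the estimated value is 50000 nM with 20000 nM to 100000 nM as its range.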

Compound 4, concentration for 50% growth inhibition: > 50000 nM
Compound 4 ended at the assay's limit; the forecaster's own chance of this, stated with the estimate: 85%; the middle value lies on the limit itself.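

In this assay, going by these compounds alone, compound 3 and compound 4 each stand only as a limit, and no step between them can be read. The compounds shown leave open whether any group on the chain gives a readable number, as the whole series rests at one limit: the limit of > 50000 nM in this assay, at which 4 of the 4 values shown sit.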